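A Fluoro Swap on an Unmeasured Compound

The source may report more compounds than this note shows. Statements on the series, on what has been measured and on what is new or still open speak of the compounds shown alone.

Going by the values given here, in a functional assay on SNU-638 cells (Homo sapiens) for cytotoxicity, read by MTT assay (on this read-out higher numbers stand for weaker inhibition and lower numbers for stronger inhibition), compound 1 (`O=C(/C=C/c1ccc(N2CCCC2)cc1)c1ccc(O)cc1`) gives 620 nM as the only number available. For compound 2 (`COc1ccc(/C=C/C(=O)c2ccc(O)cc2)cc1Br`) the result is "not determined" (no result reported) and so compound 2 has no place on the scale. Compound 3 (`COc1ccc(/C=C/C(=O)c2ccc(F)cc2)cc1Br`) differs from it in one place. The change is fluoro in place of hydroxy on an aromatic carbon and amounts to fluoro in place of hydroxy on an aromatic carbon. Among the compounds with values here, no measured step shows what such a swap does, so only a moderate step toward weaker inhibition in this assay is expected, with little certainty about its size. Compound 3 is estimated at 3000 nM with an expected range from 800 nM to 12000 nM.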

Compound 3, half-maximal inhibitory concentration: > 25000 nM
Compound 3 gave a limit, no number; the forecaster's own chance of this, stated with the estimate: 10%; at least 8.3-fold (0.92 log units) between middle value and limit.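

In this assay compound 3 gives > 25000 nM, which is a limit and not a number. Compound 2 has no number on this scale, so no step can be read between compound 2 and compound 3. On these data alone, what fluoro in place of hydroxy does in this pair stays open.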